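Bombesin receptor subtype-3 agonists: removing the nitrile

This account rests on a few compounds, and the source may have more. Where it says the series, first, only, none or still open, it means among the compounds named here.

Measured compounds and their values in an in vitro functional assay on cells for agonist activity at Bombesin receptor subtype-3 (Mus musculus), read by luminescence and calcium flux; on this read-out higher numbers stand for an effect only at larger amounts of compound and lower numbers for an effect already at smaller amounts:
compound 1 `CCCCc1cnc(C(CCC)Cc2ccc(-c3ccccc3C(=O)O)cc2)[nH]1`: 165 nM
compound 2 `CCCCc1cnc(C(Cc2ccc(-c3ccccc3C(=O)O)cc2)C(C)C)[nH]1`: 2240 nM
compound 3 `N#Cc1ccc(Cc2cnc(CCc3ccc(-c4ccccc4C(=O)O)cc3)[nH]2)cc1`: 723 nM

Compound 3 stands second highest of the three numbers in this assay; compound 1 gives a lower number and compound 2 a higher one, and both gaps are beyond the scatter. For the measured compounds named here, the only step measured, a 14-fold higher number from compound 1 to compound 2 (1.13 log units; beyond the scatter), concerns a branched chain on the shared core and has no bearing on the aryl substituent.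

Compound 4 `O=C(O)c1ccccc1-c1ccc(CCc2ncc(Cc3ccccc3)[nH]2)cc1` differs from compound 3 in one place: hydrogen in place of cyano on an aromatic carbon. Going by the values given here, no measured pair reports what happens in this assay when the cyano is removed, so no step size can be carried over from the data. The expectation therefore rests on compound 3 alone, with a wide range around its value. The estimate is for no change beyond the scatter, with a step of a 1.4-fold higher number from compound 3 to compound 4 (0.14 log units; within the scatter) expected. Compound 4 is expected at 1000 nM, in a range from 300 nM to 3500 nM.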

Compound 4, half-maximal effective concentration: 11 nM
The estimate for compound 4 lay 91-fold (1.96 log units) above the measured number, outside the stated range (below it).
By their numbers in this assay, from the lowest: compound 4; then compound 1; then compound 3; then compound 2.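

In this assay, the carbon of the six-membered aromatic ring of carbon only, para to a large group, proves highly sensitive to substitution: going from 4-cyanobenzyl to benzyl gives a 66-fold lower number from compound 3 to compound 4 (1.82 log units; beyond the scatter). For the compounds shown here, the earlier step, a 14-fold higher number from compound 1 to compound 2 (1.13 log units; beyond the scatter), concerned only a branched chain on the shared core, so this is the first measured sign that the aryl end of the series also strongly affects the read-out, and that here the cyano is a large liability relative to hydrogen. No measurement shown here accounts for the size of this step.

Going by these compounds, with only cyano and hydrogen compared at this carbon, it remains open whether a fluorine atom, a methoxy group or an amine would sit nearer compound 3 or compound 4, and thus whether the loss is specific to cyano or follows from any group at this carbon. On these data alone, it is also open whether the same change would give a step of similar size in a compound carrying the propyl branch of compound 1 on its chain.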